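A few compounds are considered here, and "the series" means these few. Any claim that something is new, unique, unknown or untested is made for them only; others in the source may bear on it.

Measured compounds:

compound 1, `COc1ccccc1C(Oc1cc(OCc2ccsc2)ccc1C#N)C(=O)O`, giving 529 nM in an assay on A10 cells for antagonist activity at Endothelin-1 receptor (Rattus norvegicus); on this read-out higher numbers stand for weaker inhibition and lower numbers for stronger inhibition
compound 2, `N#Cc1ccc(OCc2ccsc2)cc1OC(C(=O)O)c1ccccc1C(F)(F)F`, giving 53 nM in this assay
compound 3, `N#Cc1ccc(OCc2ccsc2)cc1OC(C(=O)O)c1ccc(Cl)cc1`, giving 504 nM in this assay

All three share one core and differ only in the aromatic group on the saturated chain carbon that carries the carboxylic acid. Compound 3 stands second highest of the three numbers: next to compound 1, since a 1.0-fold lower number from compound 1 to compound 3 (0.02 log units; within the scatter), and far from compound 2, since a 9.5-fold higher number from compound 2 to compound 3 (0.98 log units; beyond the scatter). Within the data shown here, the only step beyond the scatter among the three is a 10-fold lower number from compound 1 to compound 2 (1.00 log units; beyond the scatter).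

Compound 4, `N#Cc1ccc(OCc2ccsc2)cc1OC(C(=O)O)c1ccsc1`, has not yet been measured. The change from compound 3 is thiophen-3-yl in place of 4-chlorophenyl on a saturated chain carbon bound to a carbonyl carbon and an oxygen on an aromatic ring. Among the measured compounds shown here, the steps that bear on it are the two that swap the same aromatic group: from compound 1 to compound 3 the number stayed within the scatter, while from compound 2 to compound 3 it rose beyond the scatter. So this position can matter strongly or hardly at all, and no measured compound carries a thiophene there. Because a 1.0-fold lower number from compound 1 to compound 3 (0.02 log units; within the scatter) shows one such swap leaving the number in place, compound 4 is expected to stay near compound 3, with a small step of a 1.4-fold higher number from compound 3 to compound 4 (0.14 log units; within the scatter), inside a wide band. The estimate for compound 4 in this assay is 700 nM, from 200 nM to 2500 nM.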

Compound 4, half-maximal inhibitory concentration: 630 nM
Beside the measured number, compound 4's estimate is 1.1-fold (0.05 log units) above it, within the range that was stated.
By their numbers in this assay, from the lowest: compound 2; then compounds 3, 1 and 4 (each within the scatter of the next).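

Compound 4 brings a five-membered aromatic ring with a hetero atom to this position, yet in this assay its swap for 4-chlorophenyl gives a 1.3-fold higher number from compound 3 to compound 4 (0.10 log units; within the scatter) and its swap for 2-methoxyphenyl gives a 1.2-fold higher number from compound 1 to compound 4 (0.08 log units; within the scatter). The position therefore accepts three different aromatic groups, with two ring sizes and with or without a hetero atom, all within the scatter of one another, and the 2-(trifluoromethyl)phenyl group is the one that goes against this pattern, with a 12-fold higher number from compound 2 to compound 4 (1.08 log units; beyond the scatter). Nothing measured on these groups accounts for that gap, so the data give no reason for it.

The compounds shown do not tell whether the low number of compound 2 is tied to the trifluoromethyl group alone, or whether a methyl group or a bromine atom in its place on the phenyl ring would give a similar number. They also leave open what a ring without aromatic character, such as cyclohexyl, would give on the saturated chain carbon that carries the carboxylic acid.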